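This account rests on a few compounds, and the source may have more. Where it says the series, first, only, none or still open, it means among the compounds named here.

Of the compounds shown here, two have been measured in a functional assay on MCF7 cells (Homo sapiens) for cytotoxicity, read by MTT assay, with a stated time of 96 h (a lower number here means a stronger inhibitor, a higher number a weaker inhibitor), so far.

Compound 1 `COc1cc(C(=O)c2cn(-c3ccccc3)cc2-c2ccccc2C)cc(OC)c1OC` gives 190 nM here
Compound 2 `COc1cc(C(=O)c2cn(-c3ccccc3)cc2-c2ccccc2Cl)cc(OC)c1OC` gives 76 nM here

Compound 2 has the lower of the two numbers, which makes it the stronger inhibitor of this pair. Compound 3 `COc1cc(C(=O)c2cn(-c3ccccc3)cc2-c2cccc(Cl)c2)cc(OC)c1OC` has the same atoms as compound 2, joined differently, and the difference is 3-chlorophenyl in place of 2-chlorophenyl on an aromatic carbon at this one place. In plain terms, 3-chlorophenyl stands in place of 2-chlorophenyl on an aromatic carbon.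

For the measured compounds named here, only one measured step bears on this change. a 2.5-fold lower number from compound 1 to compound 2 (0.40 log units; beyond the scatter) is what chloro in place of methyl did on an aromatic carbon. That step was modest but beyond the scatter, so a change in this group can move the number. It swapped one group for another rather than shifting chlorine, so it gives no firm direction for compound 3. Going by the values given here, with compound 2 at 76 nM as the lower of only two numbers, a small rise seems the likelier result, no larger than that one step. The estimated move is a 1.6-fold higher number from compound 2 to compound 3 (0.20 log units; within the scatter) as a rough expectation. For compound 3 the expected value is 120 nM with an estimated range from 35 nM to 400 nM as a plausible span.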

Compound 3, half-maximal inhibitory concentration: 540 nM
Compound 3: middle estimate off by 4.5-fold (0.65 log units), on the low side; measured number above the stated range.
By their numbers in this assay, from the lowest: compound 2; then compound 1; then compound 3.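

In this assay, moving the chlorine from 2-chlorophenyl to 3-chlorophenyl gives a 7.1-fold higher number from compound 2 to compound 3 (0.85 log units; beyond the scatter) even though no atom is added or lost, so where the chlorine sits on this ring matters and not only whether it is present. The 3-chlorophenyl group also does worse than the 2-methylphenyl group, with a 2.8-fold higher number from compound 1 to compound 3 (0.45 log units; beyond the scatter) as the step, so having a chlorine on this ring does not by itself bring the lower number, and compound 2 remains the strongest inhibitor of the three. Nothing measured here explains why this shift of one atom has such an effect.

These three compounds cannot separate the effect of the group from the effect of its place on the ring, since 3-methylphenyl would be needed to show whether a methyl group loses ground on moving as the chlorine does. Plain phenyl, 4-chlorophenyl and 2-methoxyphenyl also remain open, so it is unclear whether 2-chlorophenyl stands out or 3-chlorophenyl falls short.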